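A few compounds are considered here, and "the series" means these few. Any claim that something is new, unique, unknown or untested is made for them only; others in the source may bear on it.

In a functional assay on MT4 cells (Homo sapiens) for cytotoxicity (on this read-out higher numbers stand for lower toxicity in this test and lower numbers for higher toxicity in this test), compound 1 (`O=C(O)CCCCCCCCCCCNC(=O)C(CO[C@@H]1O[C@H](CO)[C@H](O)[C@H](O)[C@H]1O)NC(=O)CCC(=O)O`) gives > 100000 nM, which is a limit and not a number. Compound 2 (`CCCCCCCCCCCCCCNC(=O)C(CO[C@@H]1O[C@H](CO)[C@H](O)[C@H](O)[C@H]1O)NC(=O)CCC(=O)NCCS(=O)(=O)O`) gives > 100000 nM, which is also a limit. Neither compound has an exact reading, and the two share one end of the scale: the limit of > 100000 nM in this assay, at which 2 of the 2 values shown sit. Compound 3 (`CCCCCCCCCCCCCCNC(=O)C(CO[C@@H]1O[C@H](CO)[C@H](O)[C@H](O)[C@H]1O)NC(=O)CCC(=O)O`) keeps the core of compound 2 but carries hydroxy in place of (2-sulfoethyl)amino on a carbonyl carbon. Read one bond further out, this is (2-sulfoethyl)carbamoyl to carboxy. Within the data shown here, no pair of measured compounds shows what this change does in this assay. Among the measured compounds shown here, the only guide is compound 1, which also bears a carboxy group and gives > 100000 nM, a limit. The expected change is therefore none beyond the usual scatter, in either direction: a number no higher from compound 2 to compound 3 (the limit leaves the size open). For compound 3 the estimated value is 100000 nM, with an expected range of 40000 nM to 200000 nM.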

Compound 3, half-maximal cytotoxic concentration: > 100000 nM
Compound 3: no number, only a limit; the forecaster's own chance of this, stated with the estimate: 80%; the middle value sits exactly at the limit.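

Compound 1, compound 2 and compound 3 all give a limit and not a number, so no step to compound 3 can be read from either compound 1 or compound 2: the limit of > 100000 nM in this assay, at which 3 of the 3 values shown sit.

The compounds shown leave open where each true value lies, and whether either change alters the read-out at all.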